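A few compounds are considered here, and "the series" means these few. Any claim that something is new, unique, unknown or untested is made for them only; others in the source may bear on it.

Compound 1, `NC[C@@H]1CCCc2cc(S(=O)(=O)c3cccc(F)c3)ccc21`: 0.0794 nM
Compound 2, `CNS(=O)(=O)NC[C@@H]1CCCc2cc(S(=O)(=O)c3cccc(F)c3)ccc21`: 1 nM
Compound 3, `O=S(=O)(c1cccc(F)c1)c1ccc2c(c1)CCC[C@H]2CN1CCCS1(=O)=O`: 31.6 nM

In an assay on isolated protein for displacement of a labelled ligand from 5-hydroxytryptamine receptor 6 (Homo sapiens) (on this read-out lower numbers stand for stronger inhibition and higher numbers for weaker inhibition), compound 1 gives the lowest of the three numbers; its nearest neighbour is compound 2, a 13-fold higher number from compound 1 to compound 2 (1.10 log units; beyond the scatter), and the furthest is compound 3, a 400-fold higher number from compound 1 to compound 3 (2.60 log units; beyond the scatter). Compound 4, `CN(C)C(=O)NC[C@@H]1CCCc2cc(S(=O)(=O)c3cccc(F)c3)ccc21`, has not yet been measured. It differs from compound 1 in one place: dimethylcarbamoyl in place of hydrogen on an amine nitrogen.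

For the measured compounds named here, the step that bears most directly on this change is the one from compound 1 to compound 2, where a methylsulfamoyl also entered in place of hydrogen on the same amine nitrogen and the number rose a 13-fold higher number from compound 1 to compound 2 (1.10 log units; beyond the scatter). The step to compound 3, which instead replaced the nitrogen with a five-membered ring group, was far larger, a 400-fold higher number from compound 1 to compound 3 (2.60 log units; beyond the scatter), and a 32-fold higher number from compound 2 to compound 3 (1.50 log units; beyond the scatter) separates compounds 2 and 3; it is less comparable, since compound 4 keeps an amine hydrogen as compound 2 does. Compound 4 is therefore expected to behave like compound 2, with a step beyond the scatter toward a higher number, about a 19-fold higher number from compound 1 to compound 4 (1.28 log units; beyond the scatter). The estimate for compound 4 in this assay is 1.5 nM, within a range from 0.4 nM to 6 nM.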

Compound 4, inhibition constant: 2.51 nM
The estimate for compound 4 lay 1.7-fold (0.22 log units) below the measured number, and the stated range covers the measured number.
By their numbers in this assay, from the lowest: compound 1; then compound 2; then compound 4; then compound 3.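

With dimethylcarbamoyl on the amine nitrogen, the number in this assay rises again, with a 32-fold higher number from compound 1 to compound 4 (1.50 log units; beyond the scatter) as the step, so the rise seen with methylsulfamoyl is not confined to that one group: both groups in place of hydrogen stand well above the free amine of compound 1. The two open-chain groups can also be told apart, with a 2.5-fold higher number from compound 2 to compound 4 (0.40 log units; beyond the scatter) as a modest step, small beside what either group costs relative to hydrogen on this nitrogen. Compound 4 nevertheless stays well clear of the ring-bearing compound 3, with a 13-fold lower number from compound 3 to compound 4 (1.10 log units; beyond the scatter) as the step in this assay, so the open-chain dimethylcarbamoyl group sits much nearer to compound 1 than the five-membered ring group does.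

The compounds shown leave open whether a smaller group on the same amine nitrogen, such as acetyl or a single methyl, would keep the number closer to that of compound 1. They also leave open whether a carbamoyl group carrying only one methyl would fall nearer to compound 2 or to compound 4. Nothing available gives a reason for any of these steps.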